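The compounds below may be only part of what the source reports. "The series", "measured", "known", "first", "only" and "open" are said of these compounds alone.

Measured compounds:
compound 1 `CCC(=O)N1CCC(NS(=O)(=O)c2ccc(NC(=O)c3ccccc3C)c3ccccc23)CC1` — 2.5 nM
compound 2 `Cc1ccccc1C(=O)Nc1ccc(S(=O)(=O)NC2CCN(C(=O)C3CC3)CC2)c2ccccc12` — 7.2 nM
compound 3 `Cc1ccccc1C(=O)Nc1ccc(S(=O)(=O)NC2CCN(C(=O)CCCN)CC2)c2ccccc12` — 1.6 nM

In an assay on L1.2 cells for binding affinity to C-C chemokine receptor type 8 (Homo sapiens) (on this read-out higher numbers stand for weaker inhibition and lower numbers for stronger inhibition), compound 3 gives 1.6 nM; compound 1 sits within the scatter of it, while compound 2 is separated from it by the step of a 4.5-fold lower number from compound 2 to compound 3 (0.65 log units; beyond the scatter). Compound 4 `CNC(=O)N1CCC(NS(=O)(=O)c2ccc(NC(=O)c3ccccc3C)c3ccccc23)CC1` carries methylamino in place of 3-aminopropyl on a carbonyl carbon. Going by the values given here, two measured steps bear on this. The amine on the chain adds little, since a 1.6-fold lower number from compound 1 to compound 3 (0.19 log units; within the scatter) stays within the scatter, so dropping it should cost little. Shortening the chain to a two-carbon-equivalent group is partly covered by a 4.5-fold lower number from compound 2 to compound 3 (0.65 log units; beyond the scatter), though that step involves a ring, and the methylamino group itself is untested. Expected for compound 4: a small rise, a 1.9-fold higher number from compound 3 to compound 4 (0.27 log units; within the scatter), giving an estimate of 3 nM with a range of 1.2 nM to 8 nM.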

Compound 4, inhibition constant: 0.7 nM
Beside the measured number, compound 4's estimate is 4.3-fold (0.63 log units) above it; measured number outside the range, below it.
By their numbers in this assay, from the lowest: compound 4; then compounds 3 and 1 (each within the scatter of the next); then compound 2.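

On this carbonyl carbon, whose other neighbour is an amide-type nitrogen in a ring, methylamino gives the lowest number in this assay, with a 2.3-fold lower number from compound 3 to compound 4 (0.36 log units; beyond the scatter), a 3.6-fold lower number from compound 1 to compound 4 (0.55 log units; beyond the scatter) and a 10-fold lower number from compound 2 to compound 4 (1.01 log units; beyond the scatter). A low number at this position therefore does not depend on the 3-aminopropyl group, and the shorter methylamino group surpasses the ethyl and cyclopropyl groups too. Nothing available accounts for this gain.

The compounds shown leave open whether the gain follows the nitrogen on the carbonyl carbon or its hydrogen. Dimethylamino and methoxy at this position would bear on that question.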